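The compounds below may be only part of what the source reports. "The series", "measured", "known", "first", "only" and "open" are said of these compounds alone.

Measured so far in an assay on isolated protein for inhibition of Rho-associated protein kinase 2 (Homo sapiens), read by scintillation counting, radiometric assay and 33P incorporation, with a stated time of 40 min, in the presence of a further agent that is not named here; on this read-out lower numbers stand for stronger inhibition and higher numbers for weaker inhibition:
compound 1 `CN(C)c1ccc(C(=O)Nc2cccc(NC(=O)COc3ccc4c(c3)NC(=O)CC4)c2)cc1` gives 3140 nM
compound 2 `COc1cc(OCC(=O)Nc2cccc(NC(=O)c3ccc(N(C)C)cc3)c2)ccc1C=O` gives 306 nM
compound 3 `CN(C)c1ccc(C(=O)Nc2cccc(NC(=O)COc3ccc4c(c3)OCCO4)c2)cc1` gives only a limit, > 10000 nM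

Compound 3 thus stands at the weak end of the three, with the limit of > 10000 nM in this assay, at which 1 of the 3 values shown sits, marking where its value sits; the steps of an at least 3.1-fold higher number from compound 1 to compound 3 (0.50 log units; beyond the scatter) and an at least 32-fold higher number from compound 2 to compound 3 (1.51 log units; beyond the scatter) both run toward weaker inhibition, while a 10-fold lower number from compound 1 to compound 2 (1.01 log units; beyond the scatter) runs the other way. Compound 4 `CN(C)c1ccc(C(=O)Nc2cccc(NC(=O)COc3ccc4c(c3)OCCC4=O)c2)cc1` differs from compound 3 by a group of 11 heavy atoms (9 carbon, 2 oxygen; one six-membered non-aromatic ring with 1 hetero atom, one six-membered aromatic ring of carbon only) in place of a group of 10 heavy atoms (8 carbon, 2 oxygen; one six-membered non-aromatic ring with 2 hetero atoms, one six-membered aromatic ring of carbon only), on an oxygen on a saturated carbon. The entering group resembles that of compound 1 in carrying one six-membered non-aromatic ring with one hetero atom and a carbonyl, so the step of an at least 3.1-fold higher number from compound 1 to compound 3 (0.50 log units; beyond the scatter) is the closest guide and is expected to be roughly reversed in this assay. Compound 4 is therefore estimated at 2500 nM (range 600 nM to 10000 nM), a step of an at least 4.0-fold lower number from compound 3 to compound 4 (0.60 log units; beyond the scatter) expected from compound 3.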

Compound 4, half-maximal inhibitory concentration: 85 nM
Compound 4: the middle estimate sits 29-fold (1.47 log units) above what was measured; measured number outside the range, below it.
By their numbers in this assay, from the lowest: compound 4; then compound 2; then compound 1. At a limit, above all of these: compound 3.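

Among groups with two rings on this oxygen, the read-out is not set by ring count alone: with a 3.6-fold lower number from compound 2 to compound 4 (0.56 log units; beyond the scatter), such a group ends up stronger than the single-ring group of compound 2, which compounds 1 and 3 did not show. Two equally sized groups, each with one hetero atom in the non-aromatic ring, can also lie far apart, with a 37-fold lower number from compound 1 to compound 4 (1.57 log units; beyond the scatter). The largest change is an at least 110-fold lower number from compound 3 to compound 4 (2.07 log units; beyond the scatter), and this step rests on the assay limit of compound 3: the limit of > 10000 nM in this assay, at which 1 of the 4 values shown sits.

As far as these compounds go, it remains open whether the ring carbonyl or the ring oxygen of compound 4 accounts for the gain. From the compounds shown here alone, how an amine or a hydroxyl in place of that carbonyl would read also remains open.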